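Series notes: methyl ether of compound 1 in this assay

A few compounds are considered here, and "the series" means these few. Any claim that something is new, unique, unknown or untested is made for them only; others in the source may bear on it.

Measured in a functional assay on NCI/ADR-RES cells (Homo sapiens) for inhibition, read by sulforhodamine B assay, with a stated time of 48 h, tested at 1 uM; a lower number here means a stronger effect, a higher number a weaker effect of the compound at the concentration tested:
compound 1, `O=C(Nc1cccc(-n2cc(-c3ccncc3)c(-c3cc(O)cc(Cl)c3)n2)c1)Nc1ccc(Cl)c(C(F)(F)F)c1`: 97%
compound 2, `O=C(Nc1cccc(-n2cc(-c3ccncc3)c(-c3cc(O)cc(Cl)c3)n2)c1)Nc1ccc(Cl)c(Cl)c1`: 90%

Compound 1 has the highest of the two numbers. Its nearest neighbour is compound 2, a number 7 percentage points lower from compound 1 to compound 2 (within the scatter), the step being chloro in place of trifluoromethyl on an aromatic carbon; the two read-outs therefore cannot be ordered. Both sit at the weak end of this assay.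

Compound 3, `COc1cc(Cl)cc(-c2nn(-c3cccc(NC(=O)Nc4ccc(Cl)c(C(F)(F)F)c4)c3)cc2-c2ccncc2)c1`, differs from compound 1 by methyl in place of hydrogen on an oxygen on an aromatic ring. Going by the values given here, no measured step touches this oxygen. Among the compounds with values here, the only step in hand, a number 7 percentage points lower from compound 1 to compound 2 (within the scatter), changes a different part of the molecule and lies within the scatter, so it gives no reason to expect movement from a small change at the hydroxy group either. The step is expected to be a number 2 percentage points lower from compound 1 to compound 3 (within the scatter), nothing beyond the scatter. Compound 3 is estimated at 95%, between 82% and 105%.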

Compound 3, a percentage reported as activity, at one concentration (the size of the read-out at that concentration, not a potency): 66%
Beside the measured number, compound 3's estimate is 29 percentage points above it; measured number below the stated range.
By their numbers in this assay, from the lowest: compound 3; then compounds 2 and 1 (each within the scatter of the next).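

Hydroxy to methoxy on the 3-chloro-5-hydroxyphenyl group gives a number 31 percentage points lower from compound 1 to compound 3 (beyond the scatter) in this assay and marks this oxygen as a place where the read-out responds to a small change. Going by these compounds alone, the only earlier step, a number 7 percentage points lower from compound 1 to compound 2 (within the scatter) at the other end of the molecule, stayed within the scatter and gave no sign of such a response. No measurement at hand accounts for the shift.

From the compounds shown here alone, whether the shift depends on the added methyl or on the loss of the hydroxy hydrogen stays open, and a longer ether such as ethoxy, or an amine on the same aromatic carbon, would bear on that question. Also open, going by these compounds, is whether methyl on this oxygen gives a similar shift in the dichloro urea of compound 2.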